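The source may report more compounds than this note shows. Statements on the series, on what has been measured and on what is new or still open speak of the compounds shown alone.

Compound 1 `CCOC(=O)CCCCCOc1cccc(CN(C(=O)c2ccc(-c3cccc(OCC(C)C)c3)cc2)C(C)C)c1` — in an ADME assay on Raji cells (Homo sapiens) for cytotoxicity, read by CellTiter-Glo and resazurin assay, with a stated time of 72 h (on this read-out lower numbers stand for an effect already at smaller amounts and higher numbers for an effect only at larger amounts of compound), compound 1 gives > 26000 nM, a limit of the assay rather than a number.
Compound 2 `CCOC(=O)CCCCCOc1cccc(CN(C(=O)c2ccc(-c3cccc(OCC)c3)cc2)C(C)C)c1` — in this assay compound 2 gives > 22300 nM, again a limit.
Compound 3 `CCOC(=O)CCCCCOc1cccc(CN(C(=O)c2ccc(-c3cccc(Br)c3)cc2)C(C)C)c1` — in this assay compound 3 gives > 26000 nM, also a limit.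

Compound 3 therefore stands where every measured compound stands: at a limit of the assay, with no effect seen up to the highest amount tested. Within the data shown here, the three values sit at two such limits, the limit of > 22300 nM in this assay, at which 1 of the 3 values shown sits, and (the limit of > 26000 nM in this assay, at which 2 of the 3 values shown sit), so none of the measured steps can be read: a step that the two limits leave unreadable from compound 1 to compound 2, a step that the two limits leave unreadable from compound 1 to compound 3 and a step that the two limits leave unreadable from compound 2 to compound 3 are all unreadable in size, and nothing can be said about direction.

The next compound, compound 4 `CCOC(=O)CCCCCOc1cccc(CN(C(=O)c2ccc(-c3ccc(Cl)c(Cl)c3)cc2)C(C)C)c1`, changes the outer ring of the shared core: 3,4-dichlorophenyl in place of 3-bromophenyl on an aromatic carbon. Among the measured compounds shown here, the only steps that bear on this change are the three unreadable ones above, all of which vary the same outer ring, and all of which left the compound without a measurable effect. The expectation for compound 4 is therefore no step beyond the scatter, a number no higher from compound 3 to compound 4 (the limit leaves the size open), and most likely a further limit. Compound 4 is estimated at 26000 nM in this assay, with a range from 10000 nM to 80000 nM.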

Compound 4, half-maximal effective concentration: > 26000 nM
Compound 4: only a limit was reported (the forecaster's own chance of this, stated with the estimate: 80%); the middle value sits exactly at the limit.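

Compound 4 gives > 26000 nM in this assay and this is a limit of the assay, not a number. Its steps from compound 1, compound 2 and compound 3 therefore cannot be read, in size or in direction. The compounds shown leave open whether any outer ring on the shared core gives a measurable effect in this assay at all, and how large the steps among these four compounds are.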